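This account rests on a few compounds, and the source may have more. Where it says the series, first, only, none or still open, it means among the compounds named here.

Of the compounds shown here, three built on one shared core have been tested in a functional assay on 786-0 cells (Homo sapiens) for inhibition, read by sulforhodamine B assay, with a stated time of 48 h, tested at 10 uM; on this read-out lower numbers stand for less inhibition and higher numbers for more inhibition at the one concentration tested (going by the name of the read-out). Compound 1 `c1ccc2c(-c3cn4ccnc4c(-c4ccc5ncn(C6CCCCC6)c5c4)n3)cccc2c1` gives 6.33% there. Compound 2 `Fc1ccc(-c2cn3ccnc3c(-c3ccc4ncn(C5CCCCC5)c4c3)n2)cc1` gives 11.2% in this assay, and compound 3 `Clc1ccc(-c2cn3ccnc3c(-c3ccc4ncn(C5CCCCC5)c4c3)n2)cc1` gives 12.1%. The steps between them are all small: a number 4.9 percentage points higher from compound 1 to compound 2 (within the scatter), a number 5.8 percentage points higher from compound 1 to compound 3 (within the scatter) and a number 0.9 percentage points higher from compound 2 to compound 3 (within the scatter). Within the data shown here, compound 3 therefore stands among three numbers that lie within the scatter of one another; no measured step sets it apart from either neighbour.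

Compound 4 `Brc1ccc(-c2cn3ccnc3c(-c3ccc4ncn(C5CCCCC5)c4c3)n2)cc1` is the next member of the series. The change from compound 3 is bromo in place of chloro on an aromatic carbon. Of the measured steps, the one that bears on this change is the exchange of one halogen for another at the same place, from compound 2 to compound 3, which gave a number 0.9 percentage points higher from compound 2 to compound 3 (within the scatter). The two aryl replacements from compound 1 were likewise within the scatter. On this basis compound 4 is expected to show no step beyond the scatter, with a number 0.9 percentage points higher from compound 3 to compound 4 (within the scatter) as the estimated size of the change. The estimate for compound 4 in this assay is 13%, with a range from 4% to 24%.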

Compound 4, a percentage reported as inhibition, at one concentration (the size of the read-out at that concentration, not a potency): 18%
Compound 4: middle estimate off by 5 percentage points, on the low side; measured number inside the range.
By their numbers in this assay, from the lowest: compounds 1, 2, 3 and 4 (each within the scatter of the next, the first and the last beyond it).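

In this assay the exchange of chloro for bromo on the aromatic carbon gives a number 5.9 percentage points higher from compound 3 to compound 4 (within the scatter) and the exchange of fluoro for bromo gives a number 6.8 percentage points higher from compound 2 to compound 4 (within the scatter), so at this position, para to a large group, the three halogens still cannot be told apart by any single exchange among them. Among these compounds, what the earlier compounds did not show is a step that clears the scatter: 4-bromophenyl in place of naphthalen-1-yl gives a number 11.7 percentage points higher from compound 1 to compound 4 (beyond the scatter), a modest step, whereas the 4-fluorophenyl and 4-chlorophenyl replacements of the same group stayed within the scatter, which makes bromo the only one of the three halogens whose aryl group is separated from the naphthalen-1-yl compound. No available evidence bears on why this step alone passes the scatter.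

The compounds shown leave open how an amine, a carboxylic acid or a methoxy group at this same place on the phenyl ring would read in this assay, and whether any such group would stand apart from the halogens. They also leave open whether the modest step holds when the cyclohexyl group on the shared core gives way to a longer chain.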